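The source may report more compounds than this note shows. Statements on the series, on what has been measured and on what is new or still open speak of the compounds shown alone.

Compound 1 `N#Cc1c(NN)nc(SCc2nc3ccccc3[nH]2)nc1-c1ccccc1`: 5.4 nM
Compound 2 `CCNc1nc(SCc2nc3ccccc3[nH]2)nc(-c2ccccc2)c1C#N`: 2.63 nM

Both numbers come from a functional assay on NB1 cells (Homo sapiens) for cytotoxicity, read by MTT assay, with a stated time of 3 days; a lower number here means a stronger inhibitor, a higher number a weaker inhibitor. Of the two compounds, compound 2 holds the lower number, 2.63 nM, and so stands as the stronger inhibitor, though the series measured so far is very short.

The next compound is compound 3 `N#Cc1c(Nc2nccs2)nc(SCc2nc3ccccc3[nH]2)nc1-c1ccccc1`, with the change (1,3-thiazol-2-yl in place of ethyl on a nitrogen on an aromatic ring). In words, 1,3-thiazol-2-yl stands in place of ethyl on a nitrogen on an aromatic ring, and the rest of the structure stays the same.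

Among the compounds with values here, only one measured step bears on this. It concerns the same nitrogen: a 2.1-fold lower number from compound 1 to compound 2 (0.31 log units; beyond the scatter), a modest step on swapping amino for ethyl. Within the data shown here, no measured compound carries a ring at this place, so the data give no direction for such a change. A step of similar modest size is therefore expected in this assay, leaning tentatively towards a higher number, with either direction remaining possible. The expected change is a 1.5-fold higher number from compound 2 to compound 3 (0.18 log units; within the scatter). For compound 3 the estimated value is 4 nM, with an expected range from 1.2 nM to 14 nM.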

Compound 3, half-maximal inhibitory concentration: 3.2 nM
Beside the measured number, compound 3's estimate is 1.3-fold (0.10 log units) above it; low and high end bracket the measured number.
By their numbers in this assay, from the lowest: compounds 2, 3 and 1 (each within the scatter of the next, the first and the last beyond it).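

In this assay, putting 1,3-thiazol-2-yl in place of ethyl gives a 1.2-fold higher number from compound 2 to compound 3 (0.09 log units; within the scatter), so this nitrogen on an aromatic ring carries a five-membered aromatic ring of 5 heavy atoms with no step beyond the scatter from the ethyl group of 2 heavy atoms and no ring. The comparison with the amino group reads the same way, with a 1.7-fold lower number from compound 1 to compound 3 (0.23 log units; within the scatter), which places compound 3 within the scatter of both earlier compounds, even though those two lie beyond the scatter of each other. Within the data shown here, this is the first ring seen at this place, and the single example shows that a ring can sit here with the number still in the low range of the series, but nothing available offers a reason for this result.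

The compounds shown leave open whether a longer chain such as butyl, a phenyl ring or a carboxylic acid on this same nitrogen would keep the number within this range. They also leave open how much the number depends on the rest of the shared core, which stays the same in all three compounds.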